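The source may hold more compounds than are shown below. What is called first, only, known or untested is meant among the compounds shown, and "the series" means these compounds.

In an ADME assay on Huh-7 cells (Homo sapiens) for cytotoxicity (on this read-out higher numbers stand for lower toxicity in this test and lower numbers for higher toxicity in this test), the measured compounds stand as follows:
Compound 1, `CN1CCN(CCNCc2cn(-c3ccc(F)cc3F)nc2-c2ccc(Cl)cc2)CC1`, gave 19000 nM.
Compound 2, `COC(=O)c1ccc(-c2nn(-c3ccc(F)cc3F)cc2CNCCN2CCN(C)CC2)cc1`, gave > 20000 nM, a limit of the assay.
Compound 3, `COc1ccc(-c2nn(-c3ccc(F)cc3F)cc2CNCCN2CCN(C)CC2)cc1`, gave > 20000 nM, also a limit of the assay.

Compound 3 thus stands at the limit of > 20000 nM in this assay, at which 2 of the 3 values shown sit, with no number of its own. Compound 4, `CN1CCN(CCNCc2cn(-c3ccc(F)cc3F)nc2C(C)(C)C)CC1`, is not yet measured and differs from compound 3 by tert-butyl in place of 4-methoxyphenyl on an aromatic carbon. The steps that lead into this region are an at least 1.0-fold higher number from compound 1 to compound 3 (0.02 log units; that floor lies within the scatter) and an at least 1.0-fold higher number from compound 1 to compound 2 (0.02 log units; that floor lies within the scatter), and a step that the two limits leave unreadable from compound 2 to compound 3. Taken together they show no step beyond the scatter, so none beyond the scatter is expected in this assay, in either direction. Compound 4 is therefore estimated at 20000 nM, with a range from 10000 nM to 40000 nM. That estimate means an expected a number no higher from compound 3 to compound 4 (the limit leaves the size open).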

Compound 4, half-maximal cytotoxic concentration: > 20000 nM
Compound 4 gave a limit, no number; the forecaster's own chance of this, stated with the estimate: 55%; the middle value sits exactly at the limit.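

In this assay the change to tert-butyl, which has no ring, from the 4-methoxyphenyl of compound 3 still gives a limit for compound 4, so an aromatic ring on this carbon is not required to reach that limit: the limit of > 20000 nM in this assay, at which 3 of the 4 values shown sit. The step of an at least 1.0-fold higher number from compound 1 to compound 4 (0.02 log units; that floor lies within the scatter) is the only new one that can be read, and the other new steps cannot be read.

Going by these compounds, what would bring the value down from the limit at this position stays open. An amine or a carboxylic acid here might give a first readable number.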